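Swapping the Vinyl Aryl for a Dichloro Aryl

A few compounds are considered here, and "the series" means these few. Any claim that something is new, unique, unknown or untested is made for them only; others in the source may bear on it.

Compound 2 `C=Cc1ccc(S(=O)(=O)Nc2ccc3oc(-c4ccccc4)nc3c2)cc1` was examined in an assay on cells for inhibition of HSP60/HSP10 (Homo sapiens), with a stated time of 60 min; on this read-out higher numbers stand for weaker inhibition and lower numbers for stronger inhibition. In this assay compound 2 gives only the limit of the assay, > 100000 nM, and not a number. Compound 3 `C=Cc1ccc(S(=O)(=O)Nc2ccc(-c3nc4ccccc4o3)cc2)cc1` likewise gives only a limit in this assay, > 100000 nM. Both of these limits coincide with the limit of > 100000 nM in this assay, at which 2 of the 3 values shown sit. Compound 1 `O=S(=O)(Nc1ccc(-c2nc3ccccc3o2)cc1)c1ccc(Cl)c(C(F)(F)F)c1`, by contrast, gives a measured value of 12000 nM in this assay.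

Compound 4 `O=S(=O)(Nc1ccc2oc(-c3ccccc3)nc2c1)c1ccc(Cl)c(Cl)c1` has not yet been measured. It differs from compound 2 in a single place: 3,4-dichlorophenyl in place of 4-vinylphenyl on a sulfonyl sulfur. No step between measured compounds covers this change, so the expectation rests on compound 1, whose value of 12000 nM shows that a number within the range of this assay is attainable among these compounds. The step from compound 2 to compound 4 is expected to be an at least 3.3-fold lower number from compound 2 to compound 4 (0.52 log units; beyond the scatter), towards stronger inhibition, although the limit at which compound 2 sits leaves the size of that step uncertain. Compound 4 is estimated at 30000 nM in this assay, with a range from 8000 nM to 100000 nM.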

Compound 4, half-maximal inhibitory concentration: > 100000 nM
Compound 4 ended at the assay's limit; the forecaster's own chance of this, stated with the estimate: 40%; middle value at least 3.3-fold (0.52 log units) from the limit.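

In this assay compound 4 gives > 100000 nM, which is a limit of the assay and not a number. Going by these compounds alone, compound 2 also sits at a limit, so no step between compound 2 and compound 4 can be read. The compounds shown leave open whether 3,4-dichlorophenyl in place of 4-vinylphenyl changes inhibition at all.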